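Propoxy in place of ethylsulfanyl on the shared core

The compounds below may be only part of what the source reports. "The series", "measured", "known", "first", "only" and "open" are said of these compounds alone.

Measured so far:
compound 1 `Nc1ncnc2c1nc(O)n2Cc1ccc(Cl)cc1` — 30 mg/kg
compound 2 `CCSc1nc(N)c2nc(O)n(Cc3ccccc3)c2n1` — 0.1 mg/kg
compound 3 `Nc1ncnc2c1nc(S)n2Cc1ccccc1` — a limit, > 30 mg/kg

In a functional assay on the whole organism for activation, with Mus musculus as the target (a lower number here means that less compound is needed, a higher number that more compound is needed for the effect), compound 2 gives 0.1 mg/kg, the lowest of the two numbers. Compound 1 gives 30 mg/kg in this assay, a gap beyond the scatter. For compound 3 this assay reports only a limit, > 30 mg/kg (the limit of > 30 mg/kg in this assay, at which 1 of the 3 values shown sits), not a number. No two of these compounds differ in one place alone, so no single step is measured.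

Compound 4 `CCCOc1nc(N)c2nc(O)n(Cc3ccccc3)c2n1` is not yet measured. It differs from compound 2 by propoxy in place of ethylsulfanyl on an aromatic carbon. Both groups are short chains, no ring, with one hydrogen-bond acceptor each. The step from compound 2 to compound 4 is expected to be small, a 3.0-fold higher number from compound 2 to compound 4 (0.48 log units; beyond the scatter), at most modestly toward more compound. Compound 4 is expected to give about 0.3 mg/kg, within 0.03 mg/kg to 3 mg/kg.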

Compound 4, minimum effective dose: 0.3 mg/kg
Estimate against measurement, compound 4: no gap at the digits printed; the range from low to high includes it.
By their numbers in this assay, from the lowest: compound 2; then compound 4; then compound 1.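

In this assay, this position on the shared core now has a measured step: propoxy in place of ethylsulfanyl gives a 3.0-fold higher number from compound 2 to compound 4 (0.48 log units; beyond the scatter) and lies beyond the scatter. Sulfur on this aromatic carbon is therefore not required for activity at a low dose, as compound 4 gives 0.3 mg/kg with an oxygen-linked chain, although compound 2 still needs less compound. Nothing measured here accounts for the size of this step.

Open, going by these compounds, is how a longer chain such as butoxy, or an amine, would fare at this position.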